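This account rests on a few compounds, and the source may have more. Where it says the series, first, only, none or still open, it means among the compounds named here.

In a physicochemical assay for lipophilicity, measured as octanol-water partition, at pH 7.4 (a lower number here means a more polar compound, a higher number a more lipophilic compound), compound 3 (`CC(C)c1noc(N2CCC(Oc3cc(N4CCc5cc([S+]([O-])CCO)ccc54)ncn3)CC2)n1`) gives 2.7 as the lowest of three numbers, under compound 1 (`CC(C)c1noc(N2CCC(Oc3cc(N4CCc5cc(N6CCCNS6(=O)=O)ccc54)ncn3)CC2)n1`) at 3.2 and compound 2 (`CC(C)c1noc(N2CCC(Oc3cc(N4CCc5cc(N6CCCC6=O)ccc54)ncn3)CC2)n1`) at 3.7 on the same scale. Compound 4 (`CC(C)c1noc(N2CCC(Oc3cc(N4CCc5cc(N6CCOCC6=O)ccc54)ncn3)CC2)n1`) has not yet been measured and differs from compound 3 by a group of 7 heavy atoms (4 carbon, 1 nitrogen, 2 oxygen; one six-membered non-aromatic ring with 2 hetero atoms) in place of a group of 5 heavy atoms (2 carbon, 2 oxygen, 1 sulfur; no ring), on an aromatic carbon and thereby carries a 3-oxomorpholin-4-yl group. Going by the values given here, two measured steps bear on this, both modest and both leaving a ring group for the group of compound 3 (a number 0.50 log units lower from compound 1 to compound 3 (beyond the scatter)) (a number 1.00 log units lower from compound 2 to compound 3 (beyond the scatter)). Going the other way, back to a ring group, a modest rise beyond the scatter is expected in this assay rather than no change. The estimated change is a number 0.50 log units higher from compound 3 to compound 4 (beyond the scatter) on this reading. Compound 4 is expected at 3.2 (estimated range 2.8 to 3.6).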

Compound 4, distribution coefficient: 3.1
Compound 4: middle estimate off by 0.10 log units, on the high side; low and high end bracket the measured number.
By their numbers in this assay, from the lowest: compound 3; then compounds 4 and 1 (each within the scatter of the next); then compound 2.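

In this assay, the size of a step among ring groups on this aromatic carbon depends on the ring: with 3-oxomorpholin-4-yl in place of 2-oxopyrrolidin-1-yl, the result is a number 0.60 log units lower from compound 2 to compound 4 (beyond the scatter), whereas the two six-membered rings are not separated, at a number 0.10 log units lower from compound 1 to compound 4 (within the scatter). Against the group without a ring, the new ring gives a number 0.40 log units higher from compound 3 to compound 4 (beyond the scatter), so all three ring groups stand above that group. Nothing available explains these differences. The compounds shown leave open where a morpholin-4-yl ring without the carbonyl, or a carboxylic acid on the same carbon, would fall on this scale.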